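Swapping Fluoro for Methyl on a Thiourea Quinazoline Analogue

The compounds below may be only part of what the source reports. "The series", "measured", "known", "first", "only" and "open" are said of these compounds alone.

Compound 2 `NS(=O)(=O)c1ccc(NC(=S)Nc2ccc3ncnc(Nc4cccc(F)c4)c3c2)cc1` and compound 1 `NS(=O)(=O)c1ccc(NC(=S)Nc2ccc3ncnc(Nc4ccc(F)c(Cl)c4)c3c2)cc1` share one core and differ only on the aromatic ring attached to a nitrogen. In a functional assay on NCI-H1975 cells (Homo sapiens) for antiproliferative activity, read by MTT assay, with a stated time of 72 h (a lower number here means a stronger inhibitor, a higher number a weaker inhibitor), compound 2 gives 9660 nM, while compound 1 gives 15800 nM; the step of a 1.6-fold lower number from compound 1 to compound 2 (0.21 log units; within the scatter) lies within the scatter, so the two cannot be told apart. Compound 3 `Cc1cccc(Nc2ncnc3ccc(NC(=S)Nc4ccc(S(N)(=O)=O)cc4)cc23)c1` carries methyl in place of fluoro on an aromatic carbon. For the measured compounds named here, no measured step shows this exact exchange; the one step that touches the same ring was within the scatter. A shift of a 1.0-fold higher number from compound 2 to compound 3 (0.02 log units; within the scatter) is therefore expected, nothing beyond the scatter. Compound 3 is estimated at 10000 nM, between 4000 nM and 25000 nM.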

Compound 3, half-maximal inhibitory concentration: 35400 nM
Compound 3: the middle estimate sits 3.5-fold (0.55 log units) below what was measured; the whole stated range lies below it.
By their numbers in this assay, from the lowest: compounds 2 and 1 (each within the scatter of the next); then compound 3.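

Methyl in place of fluoro on this aromatic carbon gives a 3.7-fold higher number from compound 2 to compound 3 (0.56 log units; beyond the scatter) in this assay and so shows that this position responds to a small exchange, which the step between the earlier compounds could not show. Set against 3-chloro-4-fluorophenyl, 3-methylphenyl likewise gives a 2.2-fold higher number from compound 1 to compound 3 (0.35 log units; beyond the scatter) and stands apart. Nothing measured here accounts for this shift. Going by these compounds, whether the shift comes from losing fluoro or from gaining methyl stays open. On these data alone, how an amine or a methoxy group on this same carbon would read also remains unknown.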